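A few compounds are considered here, and "the series" means these few. Any claim that something is new, unique, unknown or untested is made for them only; others in the source may bear on it.

Among the measured compounds shown here, in a functional assay on HOP-62 cells (Homo sapiens) for inhibition (a lower number here means a stronger inhibitor of growth, a higher number a weaker inhibitor of growth), compound 1 `COc1ccc(-n2cnnc2-c2cc(OC)c(OC)c(OC)c2)cc1` gives 2090 nM, the higher of the two numbers measured so far, and compound 2 `COc1cc(-c2nncn2-c2ccc(N(C)C)cc2)cc(OC)c1OC` gives 275 nM. Compound 3 `COc1ccc(-n2cnnc2-c2cc(OC)c(OC)c(OC)c2)cc1O` keeps the structure of compound 1 but has hydroxy in place of hydrogen on an aromatic carbon, ortho to a methoxy group: hydroxy in place of hydrogen on an aromatic carbon. For the measured compounds named here, no measured step adds a hydroxy, so the evidence is thin. Going by the values given here, the only guide is a different change on the same ring, dimethylamino in place of methoxy, which gave a 7.6-fold lower number from compound 1 to compound 2 (0.88 log units; beyond the scatter). That step shows that a single change on this ring can move the number beyond the scatter, but not which way a hydroxy will move it. A step of similar size towards a lower number is tentatively expected, and the estimated step is an 8.4-fold lower number from compound 1 to compound 3 (0.92 log units; beyond the scatter). For compound 3, the expected value is 250 nM, with an estimated range of 30 nM to 1800 nM.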

Compound 3, concentration for 50% growth inhibition: 490 nM
The estimate for compound 3 lay 2.0-fold (0.29 log units) below the measured number; measured number inside the range.
By their numbers in this assay, from the lowest: compounds 2 and 3 (each within the scatter of the next); then compound 1.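

Adding one hydroxy to an aromatic carbon, ortho to a methoxy group and meta to a large group, gives a 4.3-fold lower number from compound 1 to compound 3 (0.63 log units; beyond the scatter) in this assay. Among the compounds shown here, the earlier compounds showed only that replacing a group already on this ring could lower the number, whereas this step shows that adding a group where compound 1 carries only a hydrogen can lower it too. Nothing measured here explains the change.

As far as these compounds go, what remains open is whether this effect is specific to hydroxy or would also appear with another small group at this position, such as fluorine or an amine. Also open, from the compounds shown here alone, is whether hydroxy and dimethylamino on the same ring, in one compound, would lower the number further than either change alone.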